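The source may hold more compounds than are shown below. What is called first, only, known or untested is meant among the compounds shown, and "the series" means these compounds.

Measured in an ADME assay on HCT-116 cells (Homo sapiens) for cytotoxicity, read by CellTiter-Glo, with a stated time of 72 h; a higher number here means a weaker inhibitor, a lower number a stronger inhibitor:
- compound 1 `CC1CCN(C2CCN(S(=O)(=O)c3cccc(N)c3)CC2)CC1`: > 5000 nM (a limit)
- compound 2 `CC1CCN(C2CCN(S(=O)(=O)c3cccc(-c4ccccc4C(F)(F)F)c3)CC2)CC1`: > 5000 nM (a limit)

Compound 2 has no number in this assay: its > 5000 nM is a limit of the assay. The picture so far is the limit of > 5000 nM in this assay, at which 2 of the 2 values shown sit, so neither measured compound gives a number.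

Compound 3 `CC1CCN(C2CCN(S(=O)(=O)c3cccc(Br)c3)CC2)CC1` carries bromo in place of 2-(trifluoromethyl)phenyl on an aromatic carbon, (bromo in place of 2-(trifluoromethyl)phenyl on an aromatic carbon). Among the measured compounds shown here, the only measured step that bears on this change is a step that the two limits leave unreadable from compound 1 to compound 2, which altered the group on that same aromatic carbon. It offers no size and no direction to carry over, so no readable step is expected in this assay, and compound 3 is expected to stay at the limit. The expected shift, a step that the limit leaves unreadable from compound 2 to compound 3, is therefore only nominal. The estimate for compound 3 is 7000 nM, with an expected range from 3000 nM to 15000 nM.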

Compound 3, half-maximal inhibitory concentration: > 5000 nM
Compound 3 gave a limit, no number (the forecaster's own chance of this, stated with the estimate: 85%); the middle value is on the limit's open side.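

In this assay compound 3 gives > 5000 nM, a limit and not a number. The steps to compound 3 from compound 1 and compound 2 therefore cannot be read: the limit of > 5000 nM in this assay, at which 3 of the 3 values shown sit.

The compounds shown leave open what number, if any, each of the three would reach in this assay.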